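Working notes: from compound 2 to compound 4

A few compounds are considered here, and "the series" means these few. Any claim that something is new, unique, unknown or untested is made for them only; others in the source may bear on it.

Measured so far in a functional assay on HL-60 cells (Homo sapiens) for antiproliferative activity, read by MTT assay, with a stated time of 48 h; on this read-out lower numbers stand for stronger inhibition and higher numbers for weaker inhibition
- Compound 1 `CN(C)CCCn1c(N)c(-c2nc3ccccc3o2)c2nc(C#N)c(C#N)nc21` gives 390 nM
- Compound 2 `CN(C)CCCn1c(N)c(-c2nc3ccccc3n2C)c2nc(C#N)c(C#N)nc21` gives 2120 nM
- Compound 3 `CN(C)CCCCn1c(N)c(-c2nc3ccccc3n2C)c2nc(C#N)c(C#N)nc21` gives 740 nM

Compound 2 stands highest of these three values in this assay and compound 3 lies nearest to it. Compound 4 `CN(C)CCCn1c(N)c(-c2nc3cc(Cl)ccc3[nH]2)c2nc(C#N)c(C#N)nc21` is still unmeasured. It carries 5-chloro-1H-benzimidazol-2-yl in place of 1-methyl-1H-benzimidazol-2-yl on an aromatic carbon. The closest evidence is the modest step at that same aromatic carbon (a 5.4-fold higher number from compound 1 to compound 2 (0.74 log units; beyond the scatter)), where 1-methyl-1H-benzimidazol-2-yl replaced 1,3-benzoxazol-2-yl. The modest chain step (a 2.9-fold lower number from compound 2 to compound 3 (0.46 log units; beyond the scatter)) lies elsewhere and says little about this group. Among the compounds with values here, no measured compound carries 5-chloro-1H-benzimidazol-2-yl, so the size remains uncertain. Compound 1 (390 nM) also lacks the methyl group of compound 2, which points to a lower number. For compound 4 a modest step is therefore expected (a 2.7-fold lower number from compound 2 to compound 4 (0.42 log units; beyond the scatter)). For compound 4 the estimated value is 800 nM (250 nM to 2500 nM).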

Compound 4, half-maximal inhibitory concentration: 2930 nM
Beside the measured number, compound 4's estimate is 3.7-fold (0.56 log units) below it; measured number outside the range, above it.
By their numbers in this assay, from the lowest: compounds 1 and 3 (each within the scatter of the next); then compounds 2 and 4 (each within the scatter of the next).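

In this assay the exchange at this aromatic carbon gives a 1.4-fold higher number from compound 2 to compound 4 (0.14 log units; within the scatter), so the two benzimidazol-2-yl groups are not told apart here, although the change removes the methyl group and adds both a chlorine and a hydrogen-bond donor. With 1,3-benzoxazol-2-yl as the reference, the same position gives a 7.5-fold higher number from compound 1 to compound 4 (0.88 log units; beyond the scatter), which shows that a benzimidazol-2-yl group without the methyl group, at least in this 5-chloro form, does not match compound 1. No measurement shown gives a reason for this result.

The effects of the methyl group and the chlorine stay unseparated without the unsubstituted 1H-benzimidazol-2-yl group at this carbon. Also open, from the compounds shown here alone, is whether 5-chloro-1,3-benzoxazol-2-yl here, or 5-chloro-1H-benzimidazol-2-yl paired with a 4-(dimethylamino)butyl chain, would shift the number.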